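A few compounds are considered here, and "the series" means these few. Any claim that something is new, unique, unknown or untested is made for them only; others in the source may bear on it.

Measured in an assay on SK-BR-3 cells for inhibition of Aromatase (Homo sapiens); a higher number here means a weaker inhibitor, a lower number a stronger inhibitor:
compound 1 `CS(=O)(=O)Nc1ccc([N+](=O)[O-])cc1OCc1ccc2ccccc2c1` gives 2170 nM;
compound 2 `COc1ccc(COc2cc([N+](=O)[O-])ccc2N(C)S(C)(=O)=O)cc1` gives 470 nM;
compound 3 `CS(=O)(=O)Nc1ccc([N+](=O)[O-])cc1OCc1ccc(F)cc1` gives 580 nM.

Among these three, compound 2 carries the lowest number in this assay. Compound 3 sits so close to it that the two cannot be told apart within the usual scatter, so no order between compound 2 and compound 3 can be claimed; compound 1, by contrast, lies well beyond the scatter on the higher side.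

The unmeasured compound 4 `CN(c1ccc([N+](=O)[O-])cc1OCc1ccc(Br)cc1)S(C)(=O)=O` is built from compound 2 by a single change: bromo in place of methoxy on an aromatic carbon. Among the measured compounds shown here, no pair of measured compounds shows this exact change, so its size in this assay is not known from the numbers at hand. What the data do show is that compound 2 and compound 3, which carry a methoxy and a fluoro on that outer ring together with other differences, fall within the scatter of each other. On that basis a halogen in this position is not expected to move the number far, and the step from compound 2 to compound 4 is estimated to be small, most likely none beyond the scatter, as a 1.1-fold higher number from compound 2 to compound 4 (0.03 log units; within the scatter). Compound 4 is therefore expected to give about 500 nM in this assay, within a range from 200 nM to 1300 nM.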

Compound 4, half-maximal inhibitory concentration: 330 nM
Estimate against measurement, compound 4: 1.5-fold (0.18 log units) above, and the stated range covers the measured number.
By their numbers in this assay, from the lowest: compounds 4, 2 and 3 (each within the scatter of the next); then compound 1.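

Read in this assay, the change from 4-methoxyphenyl to 4-bromophenyl gives the first direct reading at this position, on an aromatic carbon para to a large group, and it comes to a 1.4-fold lower number from compound 2 to compound 4 (0.15 log units; within the scatter). Among the compounds shown here, until now, no two measured compounds had differed in one place, so the closeness of the earlier values could not be tied to this position alone; this pair shows that methoxy, with its hydrogen-bond acceptor, can leave and a single bromo atom can enter without a step beyond the scatter. The data shown offer no measured explanation for this outcome.

Still, this is a single change at one position, and it leaves open whether the number would hold with an amine, a carboxylic acid or a longer chain such as butoxy in the place of the bromo. The compounds shown also contain no pair that differs only in the methyl group on the sulfonamide nitrogen, so what that methyl contributes on its own remains unknown.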